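The source may report more compounds than this note shows. Statements on the series, on what has been measured and on what is new or still open speak of the compounds shown alone.

Compound 2 `N#C/N=C(\NCc1ccc(S(=O)(=O)c2cccc(C(F)(F)F)c2)cc1)Nc1ccncc1` carries a 3-(trifluoromethyl)phenyl on the sulfonyl sulfur, and in a physicochemical assay for solubility, with a stated time of 24 h (on this read-out lower numbers stand for lower solubility and higher numbers for higher solubility), compound 2 gives 28000 nM. Its number sits at the lower end of the two shown, but its only neighbour, compound 1 `COc1cccc(S(=O)(=O)c2ccc(CN/C(=N\C#N)Nc3ccncc3)cc2)c1`, which in this assay gives 51000 nM, is not separated from it: the step of a 1.8-fold lower number from compound 1 to compound 2 (0.26 log units; within the scatter) lies within the scatter. Compound 3 `N#C/N=C(\NCc1ccc(S(=O)(=O)c2cccc3cccnc23)cc1)Nc1ccncc1` has not yet been measured. It differs from compound 2 by quinolin-8-yl in place of 3-(trifluoromethyl)phenyl on a sulfonyl sulfur. Among the measured compounds shown here, the only measured step, from compound 1 to compound 2, also alters the ring on the sulfonyl sulfur, and it did not move the number beyond the scatter; that is the sole guide, and it says nothing about exchanging a carbon-only ring for one that brings a hetero atom and a hydrogen-bond acceptor. The expected step is therefore a 1.4-fold higher number from compound 2 to compound 3 (0.15 log units; within the scatter), leaning upward but not with confidence beyond the scatter. Compound 3 is estimated at 40000 nM, with a range from 14000 nM to 110000 nM.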

Compound 3, solubility: 18000 nM
Estimate against measurement, compound 3: 2.2-fold (0.35 log units) above; measured number inside the range.
By their numbers in this assay, from the lowest: compounds 3, 2 and 1 (each within the scatter of the next, the first and the last beyond it).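

In this assay, among the compounds shown here, the exchange on the sulfonyl sulfur now brings in a ring with a hetero atom and a hydrogen-bond acceptor for the first time, and quinolin-8-yl in place of 3-(trifluoromethyl)phenyl gives a 1.6-fold lower number from compound 2 to compound 3 (0.19 log units; within the scatter) and so does not separate the two compounds. Set against 3-methoxyphenyl, the same group gives a 2.8-fold lower number from compound 1 to compound 3 (0.45 log units; beyond the scatter) as the first step at this position to clear the scatter, though it remains a modest one, and the two smaller steps among these compounds each stay within the scatter. No measurement at hand offers an explanation for either step.

Compound 3 changes the ring count and the hetero atom count together, so the compounds shown cannot tell which of the two goes with its number, and a naphthalen-1-yl on the sulfonyl sulfur would be needed to part them. On these data alone, it also stays open how this assay would respond to a ring on the sulfonyl sulfur carrying an amine or a carboxylic acid, or to a saturated ring such as piperidine in that place.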